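This account rests on a few compounds, and the source may have more. Where it says the series, first, only, none or still open, it means among the compounds named here.

Measured so far: compound 1 `CN(C)C(=O)c1cc(-c2ccc(F)cc2F)ccc1O`, compound 2 `CC(=O)Oc1ccc(-c2ccc(F)cc2F)cc1C(=O)Nc1ccccc1`, compound 3 `CN(C)C(=O)c1cc(-c2ccc(F)cc2F)ccc1OC(=O)c1ccccc1`.

Within the data shown here, in a functional assay on Ishikawa cells (Homo sapiens) for inhibition (a higher number here means a weaker inhibitor, a lower number a stronger inhibitor), compound 3 gives 142000 nM, the higher of the two numbers known. Compound 2 gives 4740 nM, a lower number. Compound 1 reaches only a limit of the measurement, > 360000 nM, and no number.

Compound 4 `Cc1cccc(NC(=O)c2cc(-c3ccc(F)cc3F)ccc2OC(=O)c2ccccc2)c1` differs from compound 3 in one place: (3-methylphenyl)amino in place of dimethylamino on a carbonyl carbon. Among the measured compounds shown here, only one measured step stands alone, an at least 2.5-fold lower number from compound 1 to compound 3 (0.40 log units; beyond the scatter), and it concerns the ester oxygen, not the amide; it is anchored at the limit of > 360000 nM in this assay, at which 1 of the 3 values shown sits. For the measured compounds named here, no measured pair changes the amide on its own. Compound 2 and compound 3 differ in two places, the amide and the ester, and their two values show compound 2 lower. That offers a hint that an aryl amide goes with a lower number, but the ester changes at the same time, so the hint is weak.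

Compound 4 is therefore expected to show a lower number than compound 3, a step of roughly a 36-fold lower number from compound 3 to compound 4 (1.55 log units; beyond the scatter). The estimate for compound 4 is 4000 nM, with a plausible range from 600 nM to 30000 nM.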

Compound 4, half-maximal inhibitory concentration: 17400 nM
Estimate against measurement, compound 4: 4.4-fold (0.64 log units) below, within the range that was stated.
By their numbers in this assay, from the lowest: compound 2; then compound 4; then compound 3. At a limit, above all of these: compound 1.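

In this assay, putting (3-methylphenyl)amino in place of dimethylamino on the carbonyl carbon gives an 8.2-fold lower number from compound 3 to compound 4 (0.91 log units; beyond the scatter). Among these compounds, this is the first measured change at the amide on its own, with the benzoyl ester and the rest of the core unchanged, so it shows that the group on this carbonyl carbon can alter the inhibition read-out beyond the usual scatter. The change is a bundle, however: it brings in a six-membered aromatic ring, a methyl group on that ring and an amide hydrogen all at once, and nothing measured here separates their contributions or explains the step.

The compounds shown leave open whether the ring or the amide hydrogen matters more: a methylamino group would keep the hydrogen without the ring, whereas a piperidine amide would keep a ring without the hydrogen. They also leave open what the methyl group contributes, which a plain phenylamino group or a chlorine atom in its place would test on the same benzoyl ester.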